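Chloro in Place of Fluoro on the Core of Compound 1

A few compounds are considered here, and "the series" means these few. Any claim that something is new, unique, unknown or untested is made for them only; others in the source may bear on it.

Compound 1 `O=C1C(=O)N(CC(CO)NCCCNc2ccnc3cc(Cl)ccc23)c2ccc(F)cc21` was tested in an ADME assay on HCT-116 cells (Homo sapiens) for cytotoxicity, read by MTT assay, with a stated time of 48 h, tested at 0.2 uM (on this read-out higher numbers stand for a stronger effect at the one concentration tested and lower numbers for a weaker effect), where compound 1 gives -2%, a number at the low end of the three shown, all of which lie within the scatter of one another. Compound 2 `O=C1C(=O)N(CC(CO)NCCCCNc2ccnc3cc(Cl)ccc23)c2ccccc21` gives 0% in this assay, and compound 3 `O=C1C(=O)N(CC(CO)NCCNc2ccnc3cc(Cl)ccc23)c2ccc(Cl)cc21` gives 0%. Compound 4 `O=C1C(=O)N(CC(CO)NCCCNc2ccnc3cc(Cl)ccc23)c2ccc(Cl)cc21` differs from compound 1 in one place: chloro in place of fluoro on an aromatic carbon. Among the compounds with values here, no step between two measured compounds is known for this change. Because compound 1 gives -2% and the other two compounds sit within the scatter of it, the step from compound 1 to compound 4 is expected to be a number 2 percentage points higher from compound 1 to compound 4 (within the scatter), none beyond the scatter. Compound 4 is therefore estimated at 0%, in a range from -8% to 8%.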

Compound 4, a percentage reported as inhibition, at one concentration (the size of the read-out at that concentration, not a potency): 0%
Compound 4: middle estimate and measured number agree at the digits printed; measured number inside the range.
By their numbers in this assay, from the lowest: compounds 1, 2, 3 and 4 (each within the scatter of the next).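

Chloro in place of fluoro on this aromatic carbon gives, in this assay, a number 2 percentage points higher from compound 1 to compound 4 (within the scatter), the one step that isolates this position. Exchanging one of these halogens for the other therefore leaves the read-out within the scatter at the single concentration tested. Nothing shown explains this result.

From the compounds shown here alone, it remains open whether a different group at this position, such as an amine, a nitrile or a methoxy group, would move the number. Going by these compounds, it also remains open whether the same exchange would behave alike on the compound with a longer chain.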